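Nitro to amino: compound 2 to compound 3

The source may hold more compounds than are shown below. What is called first, only, known or untested is meant among the compounds shown, and "the series" means these compounds.

Of the compounds shown here, two of the shared core have been measured. In a functional assay on B16 cells (Mus musculus) for cytotoxicity, read by MTT assay, with a stated time of 3 days (a higher number here means a weaker inhibitor, a lower number a stronger inhibitor), compound 1 `COc1ccc(OC)c(C(=O)/C=C/c2ccc(N)cc2)c1` gives > 100000 nM, which is a limit of the assay and not a number. In this assay compound 2 `COc1ccc(OC)c(C(=O)/C=C/c2ccc(OC)c([N+](=O)[O-])c2)c1` gives > 100000 nM, likewise only a limit. Compound 2 therefore stands at the limit of > 100000 nM in this assay, at which 2 of the 2 values shown sit, without a number to rank it. Compound 3 `COc1ccc(OC)c(C(=O)/C=C/c2ccc(OC)c(N)c2)c1` differs from compound 2 by amino in place of nitro on an aromatic carbon. Going by the values given here, no measured step covers this change, and compound 1 also carries an amino group, so no shift beyond the scatter is expected in this assay. Compound 3 is expected at 150000 nM, in the range 50000 nM to 500000 nM. The step is expected to be a step that the limit leaves unreadable from compound 2 to compound 3.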

Compound 3, half-maximal inhibitory concentration: 2000 nM
For compound 3 the middle estimate is 75-fold (1.88 log units) above the measured one; measured number below the stated range.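

In this assay, the aromatic carbon ortho to a methoxy group proves sensitive to its substituent: amino in place of nitro gives an at least 50-fold lower number from compound 2 to compound 3 (1.69 log units; beyond the scatter), and compound 3 is the only compound shown with a number rather than a limit. The true size of this step cannot be read, as compound 2 has only a limit of the assay: the limit of > 100000 nM in this assay, at which 2 of the 3 values shown sit.

As far as these compounds go, whether an acetamido or methylamino group at this carbon would keep the activity of compound 3 remains open. Also open, from the compounds shown here alone, is the effect of a hydroxyl group in place of the methoxy group.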